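Carboxy to methoxy(methyl)carbamoyl on the saturated core

The source may report more compounds than this note shows. Statements on the series, on what has been measured and on what is new or still open speak of the compounds shown alone.

Measured in an assay on isolated protein for inhibition of Apoptosis regulator Bcl-2 (Homo sapiens), read by fluorescence polarization, with stated times of 5 min and 10 min; on this read-out higher numbers stand for weaker inhibition and lower numbers for stronger inhibition:
compound 1, `CC1(C)CCCC2=C1C[C@@H](C(=O)O)[C@H](c1ccccc1)C2`: > 23000 nM
compound 2, `COC(=O)c1ccc(NC(=O)[C@H]2CC=C(CCC=C(C)C)C[C@@H]2c2ccccc2)cc1`: > 23000 nM
compound 3, `CC(C)=CCCC1=CC[C@@H](C(=O)Nc2ccc(C(=O)O)cc2)[C@H](c2ccccc2)C1`: 2200 nM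

Compound 1 rests at a limit of this assay, not at a number; in this assay compound 1 gives > 23000 nM. Compound 2 likewise sits at a limit. Going by the values given here, compound 3, the one carrying a free carboxylic acid on its aryl amide, is the only one with a number, 2200 nM. The limit of > 23000 nM in this assay, at which 2 of the 3 values shown sit, is the edge of what this assay reports.

Compound 4, `CON(C)C(=O)[C@@H]1CC2=C(CCCC2(C)C)C[C@H]1c1ccccc1`, differs from compound 1 in one place: methoxy(methyl)amino in place of hydroxy on a carbonyl carbon. Among the compounds with values here, no step between measured compounds is known for this change, and compound 1 itself offers only a limit, so nothing measured anchors the direction. The step from compound 1 to compound 4 is therefore expected as a step that the limit leaves unreadable from compound 1 to compound 4, nothing beyond the scatter, with compound 4 expected to remain at the limit in this assay. Compound 4 is estimated at 30000 nM, with a range from 10000 nM to 100000 nM.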

Compound 4, inhibition constant: > 23000 nM
Compound 4 was reported as a limit (the forecaster's own chance of this, stated with the estimate: 85%); the middle value is on the limit's open side.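

No new step can be read between compound 1 and compound 4, since each rests at a limit and not at a number: the limit of > 23000 nM in this assay, at which 3 of the 4 values shown sit.

Still open, on these data alone, is whether methoxy(methyl)amino in place of hydroxy on a carbonyl carbon changes inhibition in a compound that gives a number.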